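The source may hold more compounds than are shown below. What is called first, only, known or untested is meant among the compounds shown, and "the series" means these compounds.

Working notes on the carbamate series. Compound 1 `Cc1nc(S(C)(=O)=O)ccc1Oc1ncnc(OC2CCN(C(=O)O[C@@H](C)CF)CC2)c1F` gives 186 nM in a functional assay on isolated protein for inhibition of Glucose-dependent insulinotropic receptor (Homo sapiens), read by HTRF and cAMP accumulation (a lower number here means that less compound is needed, a higher number that more compound is needed for the effect), and stands second highest of the three numbers: compound 3 `Cc1nc(S(C)(=O)=O)ccc1Oc1ncnc(OC2CCN(C(=O)OC3COC3)CC2)c1F` gives 326 nM, a change of a 1.8-fold higher number from compound 1 to compound 3 (0.24 log units; within the scatter), while compound 2 `Cc1nc(S(C)(=O)=O)ccc1Oc1ncnc(OC2CCN(C(=O)O[C@@H](C)C(F)(F)F)CC2)c1F` gives 9.86 nM, a change of a 19-fold lower number from compound 1 to compound 2 (1.28 log units; beyond the scatter). Compound 4 `Cc1nc(S(C)(=O)=O)ccc1Oc1ncnc(OC2CCN(C(=O)SC(C)C)CC2)c1F` differs from compound 1 by a group of 4 heavy atoms (3 carbon, 1 sulfur; no ring) in place of a group of 5 heavy atoms (3 carbon, 1 oxygen, 1 fluorine; no ring), on a carbonyl carbon. Neither measured step touches the oxygen on the carbonyl; both only vary the group on that oxygen, the large one between compound 1 and compound 2 adding fluorine, the small one between compound 1 and compound 3 exchanging the carbon group. For compound 4 a step of a 1.5-fold higher number from compound 1 to compound 4 (0.18 log units; within the scatter) is therefore estimated, not beyond the scatter, with wide uncertainty. Compound 4 is expected at 280 nM, range 60 nM to 1500 nM.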

Compound 4, half-maximal effective concentration: 6.8 nM
For compound 4 the middle estimate is 41-fold (1.61 log units) above the measured one, and the stated range ends above it.
By their numbers in this assay, from the lowest: compounds 4 and 2 (each within the scatter of the next); then compounds 1 and 3 (each within the scatter of the next).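

The group on the carbonyl carbon can change at the atom bound to it, not only further out: isopropylsulfanyl gives a 27-fold lower number from compound 1 to compound 4 (1.44 log units; beyond the scatter) and a 48-fold lower number from compound 3 to compound 4 (1.68 log units; beyond the scatter) in this assay with no fluorine in the group. Set against 1-(trifluoromethyl)ethoxy, it gives a 1.5-fold lower number from compound 2 to compound 4 (0.16 log units; within the scatter) and so does not separate from that group. No measurement at hand accounts for these steps.

Open, from the compounds shown here alone, is whether the step belongs to the sulfur or to the isopropyl group, which isopropoxy or methylsulfanyl on this carbonyl carbon would bear on.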